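Swapping the N-aryl group on a pyridazinone amide

The compounds below may be only part of what the source reports. "The series", "measured", "known", "first", "only" and "open" are said of these compounds alone.

In a functional assay on A549 cells (Homo sapiens) for cytotoxicity, read by MTT assay, with a stated time of 72 h (on this read-out higher numbers stand for weaker inhibition and lower numbers for stronger inhibition), compound 2 `Cc1cc(=O)n(-c2cccc(F)c2)nc1C(=O)Nc1ccc(Oc2ncnc3ccsc23)c(F)c1` gives 5220 nM, the lower of the two numbers measured; compound 1 `Cc1ccc(-n2nc(C(=O)Nc3ccc(Oc4ncnc5ccsc45)cc3)c(C)cc2=O)cc1` gives 11500 nM in this assay, beyond the scatter from compound 2. Compound 3 `Cc1ccc(-n2nc(C(=O)Nc3ccc(Oc4ncnc5ccsc45)c(F)c3)c(C)cc2=O)cc1` has not been measured. It differs from compound 2 by 4-methylphenyl in place of 3-fluorophenyl on an aromatic nitrogen. Among the compounds with values here, compound 1 carries this same 4-methylphenyl but lacks the second fluorine, so no single step isolates the change. A modest weakening is expected, with the step from a 1.4-fold higher number from compound 2 to compound 3 (0.16 log units; within the scatter) possibly within the scatter. Compound 3 is estimated at 7500 nM, between 3500 nM and 16000 nM.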

Compound 3, half-maximal inhibitory concentration: 5890 nM
Compound 3: the middle estimate sits 1.3-fold (0.10 log units) above what was measured; low and high end bracket the measured number.
By their numbers in this assay, from the lowest: compounds 2, 3 and 1 (each within the scatter of the next, the first and the last beyond it).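

In this assay, 4-methylphenyl in place of 3-fluorophenyl on the aromatic nitrogen gives a 1.1-fold higher number from compound 2 to compound 3 (0.05 log units; within the scatter), so these two groups cannot be told apart here. Fluoro in place of hydrogen on an aromatic carbon gives a 2.0-fold lower number from compound 1 to compound 3 (0.29 log units; within the scatter), so neither single change on its own goes beyond the scatter. No measurement shown offers an explanation for either step. Still open, as far as these compounds go, is whether an aryl group carrying an amine or a carboxylic acid on that nitrogen would give a number beyond the scatter.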